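The source may report more compounds than this note shows. Statements on the series, on what has been measured and on what is new or still open speak of the compounds shown alone.

In a physicochemical assay for solubility, measured as octanol-water partition, at pH 7.4 (a lower number here means a less soluble compound, a higher number a more soluble compound), compound 2 `CC(COc1cc(N)nc(N)n1)Nc1ccnc2cc(Cl)ccc12` gives 2140 nM, within the scatter of compound 1 `Nc1cc(OCCNc2ccnc3cc(Cl)ccc23)nc(N)n1` at 1840 nM. Compound 3 `CCC(COc1cc(N)nc(N)n1)Nc1ccnc2cc(Cl)ccc12` extends the chain further: methyl in place of hydrogen on a saturated chain carbon, two bonds along the chain from a nitrogen on an aromatic ring, the same difference read as methyl to ethyl. Going by the values given here, one measured step bears on this change: a 1.2-fold higher number from compound 1 to compound 2 (0.07 log units; within the scatter), also methyl in place of hydrogen on a saturated chain carbon. That single step gives no sign of a shift beyond the scatter, and none is expected here, with the estimate being a 1.0-fold higher number from compound 2 to compound 3 (0.01 log units; within the scatter). For compound 3, the estimated value is 2200 nM, with an expected range of 1300 nM to 3500 nM.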

Compound 3, solubility: 5680 nM
Compound 3: middle estimate off by 2.6-fold (0.41 log units), on the low side; the whole stated range lies below it.
By their numbers in this assay, from the lowest: compounds 1 and 2 (each within the scatter of the next); then compound 3.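

In this assay, the position responds to what is added there: the added carbon of methyl to ethyl gives a 2.7-fold higher number from compound 2 to compound 3 (0.42 log units; beyond the scatter), whereas the earlier methyl in place of hydrogen stayed within the scatter at a 1.2-fold higher number from compound 1 to compound 2 (0.07 log units; within the scatter). Taken together, ethyl in place of hydrogen gives a 3.1-fold higher number from compound 1 to compound 3 (0.49 log units; beyond the scatter), so the two single-carbon additions do not contribute alike in this pair of steps. Nothing on hand accounts for this difference. From the compounds shown here alone, whether a longer chain such as propyl continues the rise remains open, as does the outcome with an amine on the chain.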